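From compound 3 to compound 4: one side-chain swap

This account rests on a few compounds, and the source may have more. Where it says the series, first, only, none or still open, it means among the compounds named here.

Values measured so far in an ADME assay on HepG2 cells (Homo sapiens) for cytotoxicity (a lower number here means that less compound is tolerated, a higher number that more compound is tolerated), are as follows.
- compound 1 (`CN(C)CC#Cc1cc2ncnc(Nc3ccc(OCc4cccc(F)c4)c(Cl)c3)c2s1`) gives > 32 uM
- compound 2 (`CC(C)(C)OC(=O)N1CCN(CC#Cc2cc3ncnc(Nc4ccc(OCc5cccc(F)c5)c(Cl)c4)c3s2)CC1`) gives > 24 uM
- compound 3 (`CC(C)(C)CC#Cc1cc2c(Nc3ccc(OCc4cccc(F)c4)c(Cl)c3)ncnc2s1`) gives > 32 uM

All three entries are limits and not numbers. Among the compounds with values here, the series so far consists of the limit of > 24 uM in this assay, at which 1 of the 3 values shown sits, and the limit of > 32 uM in this assay, at which 2 of the 3 values shown sit, with nothing else to go on.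

Compound 3 stands at > 32 uM and this is a limit. It therefore has no rank among the three, since the two further values are limits as well.

Compound 4 (`Fc1cccc(COc2ccc(Nc3ncnc4sc(C#CCN5CCCC5)cc34)cc2Cl)c1`) has not yet been measured. It carries pyrrolidin-1-yl in place of tert-butyl on a saturated chain carbon bound to a triple-bonded carbon.

Within the data shown here, no two measured compounds differ in one place, and the series offers no measured step to scale this change against. No step beyond the usual scatter is expected in this assay for this change. This expectation rests on compound 3 at > 32 uM as a limit. The estimated step is an at least 1.0-fold lower number from compound 3 to compound 4 (0.02 log units; that floor lies within the scatter) and it is only an expectation.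

Compound 4 is estimated at 30 uM with an expected range from 14 uM to 64 uM in this read-out.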

Compound 4, half-maximal toxic concentration: > 30 uM
Compound 4 ended at the assay's limit (the forecaster's own chance of this, stated with the estimate: 65%); the middle value lies on the limit itself.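

In this assay compound 3 gives > 32 uM, a limit. Compound 4 gives > 30 uM, also a limit, and no step can be read between compound 3 and compound 4. The compounds shown leave open whether pyrrolidin-1-yl in place of tert-butyl on a saturated chain carbon bound to a triple-bonded carbon changes the toxic concentration at all.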